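Aminopyridine nitrile series: ring carried directly on the nitrogen

This account rests on a few compounds, and the source may have more. Where it says the series, first, only, none or still open, it means among the compounds named here.

Compound 1 `N#Cc1cnc(NCc2cnccc2C(F)(F)F)cc1N[C@H]1C[C@@H](O)C1` is the smallest member shown. In an assay on isolated protein for inhibition of protein kinase C delta type (Homo sapiens), read by TR-FRET, with a stated time of 2 h (on this read-out higher numbers stand for weaker inhibition and lower numbers for stronger inhibition), compound 1 gives > 10000 nM, a limit of the assay rather than a number. Compound 2 `CO[C@H]1CC[C@@H](Nc2cc(NCc3cnccc3C(F)(F)F)ncc2C#N)CC1` is measured at 5000 nM in this assay. Compound 3 `CO[C@H]1CC[C@H](CNc2cc(NCc3cnccc3C(F)(F)F)ncc2C#N)CC1` gives > 10000 nM in this assay, again a limit and not a number. The step of an at least 2.0-fold lower number from compound 1 to compound 2 (0.30 log units; that floor lies within the scatter) and the step of an at least 2.0-fold higher number from compound 2 to compound 3 (0.30 log units; that floor lies within the scatter) are each readable only as a floor, and a step that the two limits leave unreadable from compound 1 to compound 3 cannot be read at all; compound 3 thus stands at the limit of > 10000 nM in this assay, at which 2 of the 3 values shown sit, with no number of its own.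

Compound 4 `CC1(C)C[C@@H](Nc2cc(NCc3cnccc3C(F)(F)F)ncc2C#N)CC[C@@H]1O` differs from compound 3 by 4-hydroxy-3,3-dimethylcyclohexyl in place of (4-methoxycyclohexyl)methyl on a nitrogen on an aromatic ring. The step that bears on it is an at least 2.0-fold higher number from compound 2 to compound 3 (0.30 log units; that floor lies within the scatter), here run backwards: the ring returns directly onto the nitrogen, as in compound 2, while compound 2 against compound 1 gives no readable guidance on trading methoxy for hydroxyl. A number near that of compound 2 is the expectation, with a real chance of another limit. Compound 4 is estimated at 5000 nM, between 1500 nM and 15000 nM. The expected step is an at least 2.0-fold lower number from compound 3 to compound 4 (0.30 log units; that floor lies within the scatter).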

Compound 4, half-maximal inhibitory concentration: 2400 nM
Estimate against measurement, compound 4: 2.1-fold (0.32 log units) above; the measured number falls inside the stated range.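

Within the data shown here, on a nitrogen on an aromatic ring, 4-hydroxy-3,3-dimethylcyclohexyl in place of 4-methoxycyclohexyl gives the first step between two actual numbers in this assay, a 2.1-fold lower number from compound 2 to compound 4 (0.32 log units; beyond the scatter), so this position responds to the change, if modestly. A hydroxyl-bearing ring is not tied to the limit: 4-hydroxy-3,3-dimethylcyclohexyl in place of 3-hydroxycyclobutyl gives an at least 4.1-fold lower number from compound 1 to compound 4 (0.61 log units; beyond the scatter), and in place of (4-methoxycyclohexyl)methyl it gives an at least 4.1-fold lower number from compound 3 to compound 4 (0.61 log units; beyond the scatter), both readable only as floors. Compound 1 and compound 3 still have no number of their own, each being a limit of the assay: the limit of > 10000 nM in this assay, at which 2 of the 4 values shown sit.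

The compounds shown do not separate the hydroxyl from the two methyl groups within this change, as 4-hydroxycyclohexyl and 4-methoxy-3,3-dimethylcyclohexyl lie outside them. From the compounds shown here alone, how an amine in place of the hydroxyl would read in this assay also stays open.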